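The source may report more compounds than this note shows. Statements on the series, on what has been measured and on what is new or still open speak of the compounds shown alone.

Compound 1 `Sc1nnc(-c2cccc(Cl)c2)o1` is the stronger of the two measured compounds: in an assay (Populus sieboldii x Populus grandidentata) for inhibition of Trans-cinnamate 4-monooxygenase (Populus kitakamiensis), with a stated time of 60 min (a lower number here means a stronger inhibitor, a higher number a weaker inhibitor), compound 1 gives 210 nM, the lowest of the two numbers recorded. Among the measured compounds shown here, its only measured neighbour is compound 2 `COc1cccc(-c2nnc(S)o2)c1`, which in this assay gives 6100 nM; the step of a 29-fold higher number from compound 1 to compound 2 (1.46 log units; beyond the scatter) shows that a change of the substituent on the phenyl ring can move the number strongly. Compound 3 `Sc1nnc(-c2cc(Cl)cc(Cl)c2)o1` differs from compound 1 by a single change: chloro in place of hydrogen on an aromatic carbon. For the measured compounds named here, no measured step covers the addition of a second chloro group; the step from compound 1 to compound 2 bears on it only in showing that this ring position matters, and it concerns an exchange rather than an addition. With the chloro of compound 1 retained and a second chloro added, the number is expected to stay near that of compound 1, with any movement more likely toward a slightly lower number, so the expected step is a 1.4-fold lower number from compound 1 to compound 3 (0.15 log units; within the scatter). Compound 3 is therefore estimated at 150 nM in this assay, with a range from 40 nM to 600 nM.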

Compound 3, half-maximal inhibitory concentration: > 100000 nM
Compound 3: only a limit was reported; the forecaster's own chance of this, stated with the estimate: 5%; at least 660-fold (2.82 log units) between middle value and limit.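

Adding a chloro group on an aromatic carbon, meta to the chloro group already present, gives an at least 470-fold higher number from compound 1 to compound 3 (2.67 log units; beyond the scatter), so one added atom at this place separates a compound with a measurable number in this assay from one without. The result for compound 3 is a limit and not a number: the limit of > 100000 nM in this assay, at which 1 of the 3 values shown sits. Among the compounds shown here, the earlier step, a 29-fold higher number from compound 1 to compound 2 (1.46 log units; beyond the scatter), showed only that an exchange of the existing group can move the number, whereas this step shows that keeping the chloro of compound 1 does not protect the number when a further group enters the ring.

The compounds shown leave open whether this loss belongs to chloro as such or to any group at this place, which a fluoro, a methyl or an amine in the same position would help to settle. For the compounds shown here, they also leave open what a bare hydrogen in place of the single chloro of compound 1 would give, and the values shown offer no reason for the size of the step.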